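The compounds below may be only part of what the source reports. "The series", "measured", "known", "first", "only" and "open" are said of these compounds alone.

Measured in a functional assay on PC-3 cells (Homo sapiens) for antiproliferative activity, read by MTT assay, with a stated time of 24 h; on this read-out lower numbers stand for stronger inhibition and higher numbers for weaker inhibition:
- Compound 1 `CCn1c(C(=O)NCCC(=O)OC)ccc1C(CC)(CC)c1ccc(OCS(=O)(=O)c2ccccc2)c(C)c1`: 40400 nM
- Compound 2 `CCN(CC)CCNC(=O)c1ccc(C(CC)(CC)c2ccc(OCS(=O)(=O)c3ccccc3)c(C)c2)n1CC`: 7130 nM

Of these two, compound 2 holds the lower number, at 7130 nM. Compound 3 `CCn1c(C(=O)N[C@@H](C)CO)ccc1C(CC)(CC)c1ccc(OCS(=O)(=O)c2ccccc2)c(C)c1` keeps the shared core and carries 1-(hydroxymethyl)ethyl in place of 2-(diethylamino)ethyl on an amide-type nitrogen.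

Within the data shown here, only one measured step bears on this change: a 5.7-fold lower number from compound 1 to compound 2 (0.75 log units; beyond the scatter). That modest step, beyond the scatter, came with diethylamino replacing methoxycarbonyl on the chain. Compound 3 has no diethylamino group either, so a rise of similar size in this assay is expected, back towards compound 1. Among the measured compounds shown here, no measured compound carries the 1-(hydroxymethyl)ethyl group, so this expectation stays loose. The expected change is a 3.1-fold higher number from compound 2 to compound 3 (0.49 log units; beyond the scatter). The estimate for compound 3 is 22000 nM, with an expected range of 8000 nM to 60000 nM.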

Compound 3, half-maximal inhibitory concentration: 9520 nM
Estimate against measurement, compound 3: 2.3-fold (0.36 log units) above; the range from low to high includes it.
By their numbers in this assay, from the lowest: compounds 2 and 3 (each within the scatter of the next); then compound 1.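

In this assay, the diethylamino group proves not to be required on the amide-type nitrogen: 1-(hydroxymethyl)ethyl in place of 2-(diethylamino)ethyl gives a 1.3-fold higher number from compound 2 to compound 3 (0.13 log units; within the scatter) and so cannot be told apart from it here. Replacing 2-(methoxycarbonyl)ethyl with 1-(hydroxymethyl)ethyl gives a 4.2-fold lower number from compound 1 to compound 3 (0.63 log units; beyond the scatter) and shows that the earlier gain from compound 1 is not confined to a change that introduces an amine, which leaves compound 1 alone as the weakest of the three. Nothing available offers an explanation for this pattern.

On these data alone, it remains open whether a carboxylic acid in place of the methyl ester of compound 1 would stay as weak as that ester. Also unsettled is how a plain propyl group, without the hydroxyl, or a longer hydroxyalkyl chain on the amide-type nitrogen would compare with compound 3.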